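The compounds below may be only part of what the source reports. "The series", "measured", "known", "first", "only" and "open" are said of these compounds alone.

Working notes on the series. In a functional assay on HCC 2998 cells (Homo sapiens) for antiproliferative activity, read by sulforhodamine B assay, with a stated time of 48 h (a higher number here means that more compound is tolerated, a lower number that less compound is tolerated), compound 1 (`COc1ccc(OC)c(/C=C/c2nnc(Nc3ccc(Cl)cc3)o2)c1`) registers only a limit, > 100000 nM; this is the limit (the limit of > 100000 nM in this assay, at which 1 of the 2 values shown sits). Among the measured compounds shown here, compound 2 (`COc1ccc(OC)c(/C=C/C(=O)N/N=C/c2ccc(Cl)cc2)c1`) gives the single number in this assay, 6520 nM, and so stands alone among the values shown. Compound 3 (`COc1ccc(OC)c(/C=C/C(=O)N/N=C/c2ccccc2)c1`) differs from compound 2 by hydrogen in place of chloro on an aromatic carbon, that is 4-chlorophenyl to phenyl. For the measured compounds named here, no measured step of this kind exists; a modest shift is expected, probably toward less compound tolerated being lost, within or just beyond the scatter. Compound 3 is estimated at 9500 nM (range 3000 nM to 30000 nM), an expected step of a 1.5-fold higher number from compound 2 to compound 3 (0.16 log units; within the scatter).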

Compound 3, concentration lethal to 50% of the cells: 94500 nM
Estimate against measurement, compound 3: 9.9-fold (1.00 log units) below; the measured number lies above the stated range.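

The chloro on this aromatic carbon, para to a large group, carries much of the measured effect: in this assay, hydrogen in its place gives a 14-fold higher number from compound 2 to compound 3 (1.16 log units; beyond the scatter). Among the compounds shown here, this single-atom change is the first measured step, and it shows that the position is far from neutral. Only compound 1 remains at a limit, not a number: the limit of > 100000 nM in this assay, at which 1 of the 3 values shown sits.

On these data alone, whether fluoro, methyl or an amine at this carbon would keep the lower number of compound 2 remains open. So does whether another position on this ring responds as strongly.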